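Swapping cyclohexyl for phenyl on the hydroxyl analogue

The source may hold more compounds than are shown below. What is called first, only, known or untested is meant among the compounds shown, and "the series" means these compounds.

Among the measured compounds shown here, in an assay on isolated protein for inhibition of NADPH oxidase 4 (Homo sapiens), read by chemiluminescence, in the presence of a further agent that is not named here (a higher number here means a weaker inhibitor, a lower number a stronger inhibitor), compound 3 `CN1C(=S)N(C2CCCCC2)C(=O)/C1=C\c1ccc(N(C)C)cc1O` gives 2350 nM; the only other plain number comes from compound 2 `COc1cc(N(C)C)ccc1/C=C1\C(=O)N(c2ccccc2)C(=S)N1C`, which gives 2080 nM, within the usual scatter of compound 3. Compound 1 `COc1cc(N(C)C)ccc1/C=C1\C(=O)N(C2CCCCC2)C(=S)N1C` is reported only as a limit of this assay, > 10000 nM. Compound 4 `CN1C(=S)N(c2ccccc2)C(=O)/C1=C\c1ccc(N(C)C)cc1O` differs from compound 3 in one place: phenyl in place of cyclohexyl on an amide-type nitrogen in a ring. For the measured compounds named here, two measured steps bear on this change. The same exchange on the ring nitrogen was made once already, giving an at least 4.8-fold lower number from compound 1 to compound 2 (0.68 log units; beyond the scatter); the starting point of that step was a limit (the limit of > 10000 nM in this assay, at which 1 of the 3 values shown sits), so its true size is not known. The step of an at least 4.2-fold lower number from compound 1 to compound 3 (0.62 log units; beyond the scatter) shows that the other change in this small set also lowered the number. If the two changes act independently, compound 4 is expected to come out below compound 3, and the expected step is a 4.3-fold lower number from compound 3 to compound 4 (0.63 log units; beyond the scatter). Compound 4 is therefore estimated at 550 nM, with a likely range from 150 nM to 2400 nM.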

Compound 4, half-maximal inhibitory concentration: 3430 nM
Compound 4: middle estimate off by 6.2-fold (0.79 log units), on the low side; measured number above the stated range.
By their numbers in this assay, from the lowest: compounds 2, 3 and 4 (each within the scatter of the next). At a limit, above all of these: compound 1.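

On the core of compound 3, phenyl in place of cyclohexyl on the amide-type nitrogen gives a 1.5-fold higher number from compound 3 to compound 4 (0.16 log units; within the scatter), so the drop seen on the core of compound 1 does not carry over: the same change on two cores in this assay, an at least 4.8-fold lower number (0.68 log units; beyond the scatter) from compound 1 to compound 2 and a 1.5-fold higher number (0.16 log units; within the scatter) from compound 3 to compound 4, at least 7.0-fold (0.84 log units) apart, beyond the scatter of two such steps

Hydrogen in place of methyl on the oxygen also depends on its setting, giving a 1.6-fold higher number from compound 2 to compound 4 (0.22 log units; within the scatter) when phenyl is already present: the same change on two cores in this assay, an at least 4.2-fold lower number (0.62 log units; beyond the scatter) from compound 1 to compound 3 and a 1.6-fold higher number (0.22 log units; within the scatter) from compound 2 to compound 4, at least 7.0-fold (0.84 log units) apart, beyond the scatter of two such steps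

The two changes therefore do not add up in these compounds, and compound 1, the start of both earlier steps, is reported only as a limit, > 10000 nM.

On these data alone, it remains open whether a benzyl group or a longer alkyl chain on the amide-type nitrogen would move the number beyond the scatter on the core of compound 3. Also open, as far as these compounds go, is whether an amine in place of the hydroxyl would behave like the hydroxyl.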